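The source may report more compounds than this note shows. Statements on the series, on what has been measured and on what is new or still open speak of the compounds shown alone.

Working notes on the series. The shared core carries an acyl group on the ring nitrogen; compound 1 `O=C(C1CCCCC1)N1N=CCC1c1ccccc1` bears a cyclohexyl carbonyl, compound 2 `CC(C)(C)C(=O)N1N=CCC1c1cccc(Cl)c1` a tert-butyl carbonyl with a chlorine on the phenyl, and compound 3 `O=C(c1ccccc1)N1CCC(C(=O)N2N=CCC2c2ccccc2)CC1` a piperidine carbonyl that in turn carries a benzoyl group. In an ADME assay on microsomes (Homo sapiens) for metabolic stability (on this read-out higher numbers stand for a longer-lived compound and lower numbers for a shorter-lived compound), compound 1 gives 0.617 h, compound 2 gives 0.138 h, and compound 3 gives 1.72 h. Compound 3 thus has the highest number of the three in this assay, with compound 1 nearest and compound 2 furthest; both gaps lie beyond the scatter. Among the compounds with values here, no pair of measured compounds differs in a single place, so no measured step is available for comparison.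

Compound 4 `CCC(=O)N1CCC(C(=O)N2N=CCC2c2ccccc2)CC1` is the next compound and differs from compound 3 in one place: ethyl in place of phenyl on a carbonyl carbon. Within the data shown here, the change is small in count and no measured pair shows anything like it, so the direction rests on expectation alone. A modest downward step is expected for compound 4, a 1.7-fold lower number from compound 3 to compound 4 (0.24 log units; within the scatter), keeping the number in the region of compounds 1 and 3 rather than near compound 2. On that basis compound 4 is estimated at 1 h in this assay, with a range from 0.4 h to 2.5 h.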

Compound 4, half-life: > 2.75 h
Compound 4: only a limit was reported (the forecaster's own chance of this, stated with the estimate: 5%); middle value at least 2.7-fold (0.43 log units) from the limit.
By their numbers in this assay, from the lowest: compound 2; then compound 1; then compound 3. At a limit, above all of these: compound 4.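

For compound 4 the read-out in this assay is a limit of the assay and not a number: the limit of > 2.75 h in this assay, at which 1 of the 4 values shown sits.

This gives the series its first step in one place, on a carbonyl carbon whose other neighbours are an amide-type nitrogen in a ring, where ethyl in place of phenyl reads as an at least 1.5-fold higher number from compound 3 to compound 4 (0.20 log units; that floor lies within the scatter). At this position the six-membered aromatic ring of the benzoyl group is therefore not required for a half-life of this order, and the change to propanoyl brings none of the downward movement seen as possible beforehand, although the floor of the step lies within the scatter and the true size of the rise stays unread.

The compounds shown leave open how a longer chain such as hexanoyl, or an acyl group carrying an amine or a carboxylic acid, would behave on this same carbonyl carbon. They also leave open whether the propanoyl group would give a similar result on a core carrying chlorine on the phenyl, as in compound 2.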